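This account rests on a few compounds, and the source may have more. Where it says the series, first, only, none or still open, it means among the compounds named here.

Measured so far in an ADME assay on L02 cells (Homo sapiens) for cytotoxicity, read by MTT assay; a higher number here means a weaker inhibitor, a lower number a stronger inhibitor:
Compound 1 `COc1ccc(/C=C/C(=O)c2ccc(OC)c3c2OC(C)(C)C=C3)cc1OCC=C(C)C`: > 10000 nM, a limit
Compound 2 `C=CC(=O)Oc1cc(/C=C/C(=O)c2ccc(OC)c3c2OC(C)(C)C=C3)ccc1OC`: > 10000 nM, a limit

Compound 2 stands only at a limit, with no number to place it. For the measured compounds named here, the one other value shown is also a limit, so no order can be read between the two compounds. Compound 3 `COc1ccc(/C=C/C(=O)c2ccc(OC)c3c2OC(C)(C)C=C3)cc1CS(C)(=O)=O` differs from compound 2 in one place: (methylsulfonyl)methyl in place of (vinylcarbonyl)oxy on an aromatic carbon. Here (methylsulfonyl)methyl takes the place of (vinylcarbonyl)oxy on an aromatic carbon, ortho to a methoxy group.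

Going by the values given here, the only measured step is a step that the two limits leave unreadable from compound 1 to compound 2, with vinylcarbonyl in place of 3-methylbut-2-en-1-yl on an oxygen on an aromatic ring. It gives no size to carry over. Among the compounds with values here, the sole evidence is the limit of > 10000 nM in this assay, at which 2 of the 2 values shown sit. Neither measured compound carries (methylsulfonyl)methyl, so this support is thin.

No step beyond the scatter is expected in this assay, and no direction can be given. Another limit is the most likely report. The expected outcome is a step that the limit leaves unreadable from compound 2 to compound 3. Compound 3 is expected at about 15000 nM, with an estimated range of 6000 nM to 40000 nM.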

Compound 3, half-maximal inhibitory concentration: > 10000 nM
Compound 3 ended at the assay's limit; the forecaster's own chance of this, stated with the estimate: 75%; the middle value does not contradict the limit.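

In this assay compound 3 gives > 10000 nM, a limit and not a number. For the compounds shown here, no step can therefore be read among compound 1, compound 2 and compound 3. The compounds shown leave open whether (3-methylbut-2-en-1-yl)oxy, (vinylcarbonyl)oxy and (methylsulfonyl)methyl differ at all in this read-out, with every value sitting at one limit: the limit of > 10000 nM in this assay, at which 3 of the 3 values shown sit.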